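From a dimethylamino chain to a pyridin-3-yl group

A few compounds are considered here, and "the series" means these few. Any claim that something is new, unique, unknown or untested is made for them only; others in the source may bear on it.

In a functional assay on HeLa cells (Homo sapiens) for inhibition, with a stated time of 72 h (a higher number here means that more compound is needed for the effect, a lower number that less compound is needed), compound 2 (`COc1cc(CNCCCN(C)C)ccc1OCc1ccc(Cl)nc1`) gives 5000 nM and sits within the scatter of compound 3 (`CCOc1cc(CNCc2ccncc2)ccc1OCc1ccc(Cl)cc1`) at 2500 nM on this scale. Compound 1 (`COc1cc(OCc2ccc(Cl)cc2)ccc1CNCc1ccncc1`) at 440 nM needs clearly less compound, a gap beyond the scatter. Compound 4 (`COc1cc(CNCc2cccnc2)ccc1OCc1ccc(Cl)nc1`) differs from compound 2 in one place (pyridin-3-yl in place of 2-(dimethylamino)ethyl on a saturated chain carbon bound to an amine nitrogen) on a saturated chain carbon bound to an amine nitrogen. Compound 1 at 440 nM and compound 3 at 2500 nM also carry a ring on that amine, yet they differ elsewhere and only compound 1 stands apart from compound 2. A modest lowering is therefore expected, with an estimated 3.3-fold lower number from compound 2 to compound 4 (0.52 log units; beyond the scatter) in this assay as the likely step. Compound 4 is estimated at 1500 nM (range 450 nM to 5000 nM).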

Compound 4, half-maximal effective concentration: 5000 nM
The estimate for compound 4 lay 3.3-fold (0.52 log units) below the measured number; the measured number falls inside the stated range.
By their numbers in this assay, from the lowest: compound 1; then compounds 3, 2 and 4 (each within the scatter of the next).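

In this assay, putting pyridin-3-yl in place of 2-(dimethylamino)ethyl on a saturated chain carbon bound to an amine nitrogen gives no change at the digits printed from compound 2 to compound 4 (within the scatter). For this pair, then, exchanging an open chain ending in an amine for an aromatic ring does not by itself lower the number. No measurement here offers an explanation for this result. Still open, on these data alone, is whether a phenyl ring, a pyridin-2-yl group or a longer chain at this place would shift the number, and whether a carboxylic acid would.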